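Swapping the Amide Substituent: From Compound 2 to Compound 4

The source may hold more compounds than are shown below. What is called first, only, known or untested is meant among the compounds shown, and "the series" means these compounds.

Of the compounds shown here, three built on one shared core have been tested in a functional assay on BXPC-3 cells (Homo sapiens) for inhibition, read by MTT assay, with a stated time of 7 days; a higher number here means a weaker inhibitor, a lower number a stronger inhibitor. Compound 1, `CCOC(=O)[C@@H]1CCCN(S(=N)(=O)c2ccc(S(=O)(=O)N(CC)CC)cc2)C1`, gives 13300 nM. Compound 2, `CCN(CC)S(=O)(=O)c1ccc(S(=O)(=O)N2CCC[C@@H](C(=O)N[C@@H]3CCN(C(=O)OC(C)(C)C)C3)C2)cc1`, gives 400 nM. Compound 3, `CCN(CC)S(=O)(=O)c1ccc(S(=O)(=O)N2CCC[C@@H](C(=O)N3CCC(c4nc(C(C)C)no4)CC3)C2)cc1`, gives 300 nM. Among these numbers compound 2 stands second highest: its nearest neighbour is compound 3, whose number lies within the scatter of its own, and its furthest is compound 1, whose number lies beyond the scatter above it.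

Compound 4, `CCN(CC)S(=O)(=O)c1ccc(S(=O)(=O)N2CCC[C@@H](C(=O)NC3CN(S(C)(=O)=O)C3)C2)cc1`, is not yet measured. It differs from compound 2 in one place:

1-(methylsulfonyl)azetidin-3-yl in place of 1-(tert-butoxycarbonyl)pyrrolidin-3-yl on an amide-type nitrogen

Among the measured compounds shown here, no measured pair in this set isolates a change of this kind, so its size cannot be read off from existing steps. For the measured compounds named here, the one thing the numbers do show is that the amide side accepts quite different substituents, because compound 2 gives 400 nM while compound 3 gives 300 nM with an unrelated group there. On that basis the step from compound 2 to compound 4 is expected to be small, a 1.5-fold higher number from compound 2 to compound 4 (0.18 log units; within the scatter), leaning towards a slightly higher number but quite possibly none beyond the scatter. Compound 4 is therefore estimated at 600 nM, with a range from 150 nM to 3000 nM.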

Compound 4, half-maximal inhibitory concentration: 7400 nM
Beside the measured number, compound 4's estimate is 12-fold (1.09 log units) below it, outside the stated range (above it).
By their numbers in this assay, from the lowest: compounds 3 and 2 (each within the scatter of the next); then compounds 4 and 1 (each within the scatter of the next).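

In this assay, the amide-type nitrogen turns out to be a sensitive place: 1-(methylsulfonyl)azetidin-3-yl in place of 1-(tert-butoxycarbonyl)pyrrolidin-3-yl gives a 19-fold higher number from compound 2 to compound 4 (1.27 log units; beyond the scatter), a large step beyond the scatter. Among the compounds shown here, the earlier compounds offered no pair differing in one place, so this is the first direct reading at this position, and it shows that a single exchange of substituent there can shift the number substantially. The exchange changes several things at once, replacing a five-membered ring with a four-membered one, tert-butoxycarbonyl with methylsulfonyl, and a larger group with a smaller one while removing a defined stereocentre, and nothing available ties the step to any one of these differences.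

The compounds shown leave open whether ring size or the group on the ring nitrogen accounts for the step, a question that 1-(methylsulfonyl)pyrrolidin-3-yl or 1-(tert-butoxycarbonyl)azetidin-3-yl would separate. Also open, as far as these compounds go, is how an acetyl or a benzyl group on that ring nitrogen would read in this assay.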